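Ethynyl in place of but-3-en-1-yl: a paired comparison

The source may hold more compounds than are shown below. What is called first, only, known or untested is meant among the compounds shown, and "the series" means these compounds.

Compound 1 `C=CCCCSC[C@H](N)C(=O)OC` and compound 2 `C#CCSC[C@H](N)C(=O)OC` share one core, while compound 3 `C=CCCCSC[C@H](NC(=O)c1cc(O)cc(O)c1)C(=O)OC` and compound 4 `C#CCSC[C@H](NC(=O)c1cc(O)cc(O)c1)C(=O)OC` share another. The difference between the two cores is not broken down here. In an assay on RAW264.7 cells for antagonist activity at Toll-like receptor 2 (Mus musculus), read by Griess assay, with a stated time of 24 h (a higher number here means a weaker inhibitor, a lower number a stronger inhibitor), compound 1 gives 31300 nM, compound 2 gives 94400 nM and compound 3 gives 57800 nM. The numbers for compound 3 and compound 1 lie within the scatter of each other, as do those for compound 3 and compound 2, so nothing is read from those two gaps.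

The change from compound 1 to compound 2 is ethynyl in place of but-3-en-1-yl on a saturated chain carbon bound to a sulfur and is measured as a 3.0-fold higher number from compound 1 to compound 2 (0.48 log units; beyond the scatter). The same change, (ethynyl in place of but-3-en-1-yl on a saturated chain carbon bound to a sulfur), carries compound 3 into compound 4; the place is the same saturated chain carbon bound to a sulfur in both pairs, so it is taken as the same change. Compound 4 has not yet been measured in this assay.

One measured precedent is a thin base, and it sits on a different core, so the direction is taken over with more confidence than the size. Compound 4 is expected to give a higher number than compound 3, a step estimated as a 2.6-fold higher number from compound 3 to compound 4 (0.41 log units; beyond the scatter), resting on the precedent a 3.0-fold higher number from compound 1 to compound 2 (0.48 log units; beyond the scatter). The value of compound 4 in this assay is accordingly estimated at 150000 nM, expected to fall between 70000 nM and 350000 nM.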

Compound 4, half-maximal inhibitory concentration: 41800 nM
Estimate against measurement, compound 4: 3.6-fold (0.55 log units) above, outside the stated range (below it).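

In this assay, ethynyl in place of but-3-en-1-yl on a saturated chain carbon bound to a sulfur gives a 1.4-fold lower number from compound 3 to compound 4 (0.14 log units; within the scatter), so on the core of compound 3 the change has no readable effect. Set beside the earlier pair, the change does not behave as one fixed step on the two cores: the same change on two cores in this assay, a 3.0-fold higher number (0.48 log units; beyond the scatter) from compound 1 to compound 2 and a 1.4-fold lower number (0.14 log units; within the scatter) from compound 3 to compound 4, 4.2-fold (0.62 log units) apart, beyond the scatter of two such steps. Among the compounds shown here, the step read on the core of compound 1 therefore cannot serve as a guide to size or direction on the core of compound 3, though with only one pair on each core these data neither explain the difference between the cores nor give a rule for any further core.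

Still open, from the compounds shown here alone, is whether the change stays without a readable effect on the core of compound 3 when the chain itself is varied further, for example with a longer chain carrying a terminal alkyne or a saturated chain of the same length as pent-4-en-1-yl. Also open, going by these compounds, is whether a carboxylic acid in place of the methyl ester would leave the two pairs as different from each other as they are here.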